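Swapping the Side Chain Amide for a Thioether

This account rests on a few compounds, and the source may have more. Where it says the series, first, only, none or still open, it means among the compounds named here.

Four compounds share a core and differ mainly in the amino acid side chain. Compound 1 `NC(=O)CC[C@H](NC(=O)CN(c1ncnc2c1ncn2C1CCCCO1)C1CC1)C(=O)OCc1ccccc1` carries a carbamoyl-bearing side chain and a benzyl ester; in a functional assay on the whole organism (Tail, strain ICR) with Mus musculus as the target, in the tail flick test, with a stated time of 30 min, at a dose of 25 umol/kg by the oral route (on this read-out higher numbers stand for a stronger effect at the one dose given and lower numbers for a weaker effect), compound 1 gives 47%, the highest of the three measured numbers. Compound 2 `CC[C@H](C)[C@H](NC(=O)CN(c1nc(Cl)nc2[nH]cnc12)C1CC1)C(=O)O` gives 30.3% and compound 3 `NCCCC[C@H](NC(=O)CN(c1nc(Cl)nc2[nH]cnc12)C1CC1)C(=O)O` gives 31.2%; these two sit on a chlorinated core with a free acid, and the change of a number 0.9 percentage points higher from compound 2 to compound 3 (within the scatter) shows that exchanging one side chain for another there left the read-out essentially unchanged.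

Compound 4 `CSCC[C@H](NC(=O)CN(c1ncnc2c1ncn2C1CCCCO1)C1CC1)C(=O)OCc1ccccc1` is the compound now in question. It is derived from compound 1 by the change (methylsulfanyl in place of carbamoyl on a saturated chain carbon, three bonds along the chain from an amide-type nitrogen and a carbonyl carbon).

Among the measured compounds shown here, the only measured step touching a side chain is the one from compound 2 to compound 3, which lay within the scatter, so a side-chain exchange is expected to move the read-out little, if at all. The expectation for compound 4 is therefore a step of a number 2 percentage points lower from compound 1 to compound 4 (within the scatter), which amounts to no change beyond the scatter. Compound 4 is estimated to give 45%, within a range from 30% to 60%.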

Compound 4, a percentage reported as activity, at one dose (the size of the read-out at that dose, not a potency): 30%
Compound 4: middle estimate off by 15 percentage points, on the high side, within the range that was stated.
By their numbers in this assay, from the lowest: compounds 4, 2 and 3 (each within the scatter of the next); then compound 1.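

The side chain at this position does matter for the read-out: with the shared core and benzyl ester held constant, the step is a number 17 percentage points lower from compound 1 to compound 4 (beyond the scatter) in this assay. The earlier side-chain step, a number 0.9 percentage points higher from compound 2 to compound 3 (within the scatter), lay on a different core with a free acid, so it could not show this. Here the swap removes the hydrogen-bond donor and the double bond of carbamoyl and brings in sulfur, but nothing measured explains the drop or separates these differences.

On these data alone, it remains open which of these differences counts, and a carboxylic acid, a primary amine or a hydroxyl in place of carbamoyl would help to separate them. A longer chain carrying the carbamoyl would test how much the chain length matters at this position.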